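The compounds below may be only part of what the source reports. "The series", "measured", "known", "first", "only" and "open" are said of these compounds alone.

In a physicochemical assay for solubility, at pH 6.8 (on this read-out higher numbers stand for higher solubility and lower numbers for lower solubility), two compounds have numbers so far:

compound 1 `Cc1cncc(NC(=O)n2ccc3cc(Oc4ncnc5c4CCNC5)ccc32)c1` gives 190000 nM
compound 2 `CC(C)c1cc(NC(=O)n2ccc3cc(Oc4ncnc5c4CCNC5)ccc32)n[nH]1` gives 833000 nM

Compound 2 stands highest of the two. Compound 3 `CC(C)(C)c1cc(NC(=O)n2ccc3cc(Oc4ncnc5c4CCNC5)ccc32)n[nH]1` differs from it by isopropyl to tert-butyl, that is methyl in place of hydrogen on a saturated chain carbon bound to an aromatic carbon and two saturated chain carbons and nothing else. For the measured compounds named here, no measured step makes this change. The only one, a 4.4-fold higher number from compound 1 to compound 2 (0.64 log units; beyond the scatter), exchanges a whole group and so bears only loosely. A smaller, slightly downward move, a 1.7-fold lower number from compound 2 to compound 3 (0.22 log units; within the scatter), is therefore expected in this assay and may not clear the scatter. Compound 3 is estimated at 500000 nM with an expected range from 170000 nM to 1200000 nM.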

Compound 3, solubility: 682000 nM
For compound 3 the middle estimate is 1.4-fold (0.13 log units) below the measured one; the range from low to high includes it.
By their numbers in this assay, from the lowest: compound 1; then compounds 3 and 2 (each within the scatter of the next).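

In this assay, methyl in place of hydrogen on the saturated chain carbon, which turns isopropyl into tert-butyl, gives a 1.2-fold lower number from compound 2 to compound 3 (0.09 log units; within the scatter) and so makes no change that can be told from the scatter. With 5-(tert-butyl)-1H-pyrazol-3-yl in place of 5-methylpyridin-3-yl, the exchange gives a 3.6-fold higher number from compound 1 to compound 3 (0.56 log units; beyond the scatter) and so stays beyond the scatter with this larger group as well. Nothing measured here explains either step. As far as these compounds go, whether an amine, a carboxylic acid or a longer chain at this carbon would move the number beyond the scatter remains open.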